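A few compounds are considered here, and "the series" means these few. Any claim that something is new, unique, unknown or untested is made for them only; others in the source may bear on it.

The compounds here are compared in a physicochemical assay for solubility; a higher number here means a more soluble compound, a lower number a less soluble compound. Compound 1 `CNC(=O)c1cc(C(=O)NC2CC2)cn(Cc2ccc(F)cc2)c1=O` carries a 4-fluorophenyl group on the shared core. Compound 1 reads >= 162 ug/mL, and this is a limit of the measurement rather than an exact number. Compound 3 `CNC(=O)c1ccc(=O)n(Cc2ccccc2)c1` reads >= 108 ug/mL, which is also a limit. Going by the values given here, compound 2 `CNC(=O)c1cc(C(=O)NCC(C)C)cn(Cc2ccccc2)c1=O` is the only one with an exact number, at 43 ug/mL. Compound 1 therefore stands at a limit, and its exact value is not known.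

Compound 4 `CNC(=O)c1cc(C(=O)NC2CC2)cn(Cc2cccc3cn[nH]c23)c1=O` has not yet been measured. It keeps the core of compound 1 but has 1H-indazol-7-yl in place of 4-fluorophenyl on a saturated chain carbon bound to an aromatic nitrogen. Among the compounds with values here, no two measured compounds differ by this one change, so the data give no direct size for it, and any forecast is a judgement. Compound 2, at 43 ug/mL, gives the only exact reference point, although it differs from compound 4 in more than one place. A downward move beyond the usual scatter is expected, and the estimated step is an at least 2.7-fold lower number from compound 1 to compound 4 (0.43 log units; beyond the scatter). For compound 4, the expected value in this assay is 60 ug/mL, with an estimated range from 15 ug/mL to 170 ug/mL.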

Compound 4, solubility: >= 181 ug/mL
Compound 4: a limit, no number (the forecaster's own chance of this, stated with the estimate: 20%); middle value at least 3.0-fold (0.47 log units) from the limit.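

Compound 1 and compound 4 both stand at limits of the measurement in this assay, not at exact numbers, and the step between them cannot be read. The compounds shown leave open whether 1H-indazol-7-yl in place of 4-fluorophenyl changes the read-out at all, and in which direction.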